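Fluoro substitution on the aryl group of compound 3

The compounds below may be only part of what the source reports. "The series", "measured", "known", "first", "only" and "open" are said of these compounds alone.

Of the compounds shown here, three have been measured in an assay on isolated protein for inhibition of RAC-alpha serine/threonine-protein kinase (Homo sapiens), tested at 30 uM; a higher number here means more inhibition at the concentration tested (going by the name of the read-out), a lower number less inhibition. Compound 1 `Fc1ccc(-[n+]2c[nH]c3ncncc32)cc1` gives 0%. Compound 2 `Nc1ncnc2c1ncn2Cc1ccc(F)cc1` gives 0%. Compound 3 `Cn1cnc2c(-c3ccccc3)ncnc21` gives 15%, the highest of the three numbers; its nearest neighbour is compound 1, a number lower by a margin beyond the scatter, and compound 2 lies equally far below it. Compound 1 and compound 2 are within the scatter of each other and are not ordered here.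

The next compound, compound 4 `Cn1cnc2c(-c3ccc(F)cc3)ncnc21`, differs from compound 3 in one place: fluoro in place of hydrogen on an aromatic carbon, the new atom sitting on a six-membered aromatic ring of carbon only, para to a large group. Among the measured compounds shown here, no step of this kind has been measured, so the size of the change in this assay is open; compound 1 and compound 2, which both carry a fluorinated aryl group on different cores, offer no direct guidance. A step of no more than the scatter is expected, since a single fluoro on an aromatic carbon seldom moves a read-out of this kind far on its own.

For compound 4 in this assay, the expected value is 15%, with a range from 0% to 35%. The expected step is no change at the digits printed from compound 3 to compound 4 (within the scatter), which amounts to no change beyond the scatter.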

Compound 4, a percentage reported as inhibition, at one concentration (the size of the read-out at that concentration, not a potency): 0%
Compound 4: middle estimate off by 15 percentage points, on the high side; the range from low to high includes it.
By their numbers in this assay, from the lowest: compounds 1, 2 and 4 (each within the scatter of the next); then compound 3.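

In this assay, fluoro in place of hydrogen on an aromatic carbon, para to a large group, gives a number 15 percentage points lower from compound 3 to compound 4 (beyond the scatter). Among the compounds shown here, this is the first measured step at this position, and it shows a lower number with one added fluorine atom: compound 3 gives 15% and compound 4 gives 0% in this read-out. Nothing available explains this drop.

From the compounds shown here alone, whether the loss is specific to fluoro remains open, as does the response at this place to a chloro, a methoxy, an amine or a carboxylic acid, or to fluoro on another carbon of the same ring. These read-outs come from a single concentration, so they leave the potency of compound 3 and compound 4 undefined.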